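Pyrrolidine to piperidine on the propoxy chain, two cores

This account rests on a few compounds, and the source may have more. Where it says the series, first, only, none or still open, it means among the compounds named here.

Measured so far:
Compound 1, `COc1cc2c(Oc3ccc(NC(=O)c4nn(-c5ccccc5C)c(=O)cc4C)cc3F)ccnc2cc1OCCCN1CCCC1`: 1400 nM
Compound 2, `COc1cc2c(Oc3ccc(NC(=O)c4nn(-c5ccccc5C)c(=O)cc4C)cc3F)ccnc2cc1OCCCN1CCCCC1`: 2810 nM
Compound 3, `COc1ccc(-n2nc(C(=O)Nc3ccc(Oc4ccnc5cc(OCCCN6CCCC6)c(OC)cc45)c(F)c3)c(C)cc2=O)cc1`: 3300 nM

All three were run in a functional assay on HT-29 cells (Homo sapiens) for inhibition, read by MTT assay, with a stated time of 72 h; on this read-out higher numbers stand for weaker inhibition and lower numbers for stronger inhibition. Compound 1 gives 1400 nM in this assay, compound 2 gives 2810 nM, and compound 3 gives 3300 nM. Compound 3 stands highest of the three, yet its gap to compound 2 is within the scatter, so only compound 1 is separated from it.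

Compound 1 and compound 3 differ in their cores; the counted difference is 4-methoxyphenyl in place of 2-methylphenyl on an aromatic nitrogen. This step is a 2.4-fold higher number from compound 1 to compound 3 (0.37 log units; beyond the scatter).

Compound 4, `COc1ccc(-n2nc(C(=O)Nc3ccc(Oc4ccnc5cc(OCCCN6CCCCC6)c(OC)cc45)c(F)c3)c(C)cc2=O)cc1`, has not yet been measured. It differs from compound 3 by piperidin-1-yl in place of pyrrolidin-1-yl on a saturated chain carbon, three bonds along the chain from an oxygen on an aromatic ring. The same change, made on the core of compound 1, is piperidin-1-yl in place of pyrrolidin-1-yl on a saturated chain carbon, three bonds along the chain from an oxygen on an aromatic ring; both changes sit at the same place, so this is the same change on a second core. Its step there was a 2.0-fold higher number from compound 1 to compound 2 (0.30 log units; within the scatter), a step that does not exceed the scatter.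

For compound 4 the expectation is a step of about the same size, a 1.8-fold higher number from compound 3 to compound 4 (0.26 log units; within the scatter), resting on compound 1 to compound 2, a 2.0-fold higher number from compound 1 to compound 2 (0.30 log units; within the scatter), and on compound 3 as the starting point with 3300 nM. Compound 4 is therefore estimated at 6000 nM in this assay, with the range 3000 nM to 13000 nM. Whether the change carries over identically on the core of compound 3 cannot be told from a single prior pair.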

Compound 4, half-maximal inhibitory concentration: 3200 nM
Estimate against measurement, compound 4: 1.9-fold (0.27 log units) above, and the stated range covers the measured number.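

In this assay, piperidin-1-yl in place of pyrrolidin-1-yl on the core carrying 4-methoxyphenyl gives a 1.0-fold lower number from compound 3 to compound 4 (0.01 log units; within the scatter), and the change does not read differently on the two cores: the same change on two cores in this assay, a 2.0-fold higher number (0.30 log units; within the scatter) from compound 1 to compound 2 and a 1.0-fold lower number (0.01 log units; within the scatter) from compound 3 to compound 4, 2.1-fold (0.32 log units) apart, within the scatter of two such steps. The aromatic nitrogen change, read with piperidin-1-yl on the chain, gives a 1.1-fold higher number from compound 2 to compound 4 (0.06 log units; within the scatter), and although only its step with pyrrolidin-1-yl lies beyond the scatter, the two steps are not separated from each other: the same change on two cores in this assay, a 2.4-fold higher number (0.37 log units; beyond the scatter) from compound 1 to compound 3 and a 1.1-fold higher number (0.06 log units; within the scatter) from compound 2 to compound 4, 2.1-fold (0.32 log units) apart, within the scatter of two such steps. This shows no dependence of the amine change on the core in these compounds, and the amine step lies within the scatter on both cores, but two pairs in a single cell assay do not show that the steps are identical or that the change would carry over to any further core.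

The compounds shown leave open how other groups at the end of the 3-(pyrrolidin-1-yl)propyl chain would read, such as morpholin-4-yl or an open-chain dimethylamino group. They also leave open whether a shorter or longer chain, or a third substituent on the aromatic nitrogen, would give a step beyond the scatter.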